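The source may report more compounds than this note shows. Statements on the series, on what has been measured and on what is new or still open speak of the compounds shown alone.

Working notes on the series. Of the compounds shown here, two of the shared core have been measured in a functional assay on MT4 cells (Homo sapiens) for antiproliferative activity, read by MTT assay, with a stated time of 96 h; on this read-out higher numbers stand for an effect only at larger amounts of compound and lower numbers for an effect already at smaller amounts. Compound 1 (`COC(=O)/C(=C\c1c[nH]c2ccccc12)S(=O)(=O)c1ccccc1`) gives in this assay only a limit, > 100000 nM. Compound 2 (`CS(=O)(=O)/C(C#N)=C/c1c[nH]c2ccccc12`) gives in this assay likewise only a limit, > 100000 nM. Where compound 2 stands is thus set by the limit of > 100000 nM in this assay, at which 2 of the 2 values shown sit; no order between compound 1 and compound 2 can be read from these values, and no step between measured compounds is available.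

Compound 3 (`N#C/C(=C\c1c[nH]c2ccccc12)S(=O)(=O)c1ccccc1`) differs from compound 2 by phenyl in place of methyl on a sulfonyl sulfur. Compound 1 already carries phenyl on the sulfonyl sulfur and reaches in this assay only the limit > 100000 nM. Compound 2 carries the nitrile and reaches in this assay only the limit > 100000 nM. The step expected in this assay is a step that the limit leaves unreadable from compound 2 to compound 3, none beyond the scatter. For compound 3 the estimate in this assay is 150000 nM, with a range from 50000 nM to 500000 nM, and a limit rather than a number is expected.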

Compound 3, half-maximal effective concentration: > 100000 nM
Compound 3: a limit, no number (the forecaster's own chance of this, stated with the estimate: 80%); the middle value lies beyond the limit too.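

No step can be read from compound 2 or compound 1 to compound 3, because all three results are limits and not numbers: the limit of > 100000 nM in this assay, at which 3 of the 3 values shown sit.

The compounds shown leave open whether any change on the shared core gives a readable value in this assay.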